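Amino for nitro on compound 2

The compounds below may be only part of what the source reports. "The series", "measured", "known", "first", "only" and "open" are said of these compounds alone.

In an ADME assay on TZM cells (Homo sapiens) for cytotoxicity, read by XTT assay, with a stated time of 4 days (on this read-out higher numbers stand for lower toxicity in this test and lower numbers for higher toxicity in this test), compound 1 `Cc1cc(/C=C/C(=O)O)cc(C)c1Oc1ccc([N+](=O)[O-])c(Nc2ccc(C#N)cc2)n1` gives 27800 nM. Compound 2 `Cc1cc(/C=C/C#N)cc(C)c1Oc1ccc([N+](=O)[O-])c(Nc2ccc(C#N)cc2)c1` gives only a limit, > 48700 nM, so its true position is not fixed by a number. Compound 3 `Cc1cc(/C=C/C#N)cc(C)c1Oc1cc(Nc2ccc(C#N)cc2)c([N+](=O)[O-])cc1[N+](=O)[O-]` likewise gives only a limit, > 43900 nM. Compound 4 `Cc1cc(/C=C/C#N)cc(C)c1Oc1ccc(N)c(Nc2ccc(C#N)cc2)c1` differs from compound 2 by amino in place of nitro on an aromatic carbon, with amino in place of nitro on an aromatic carbon, ortho to a (4-cyanophenyl)amino group. Going by the values given here, the only measured change involving a nitro group is a step that the two limits leave unreadable from compound 2 to compound 3, so it offers no size to carry over. Only a small move towards lower numbers in this assay is therefore expected, estimated as an at least 1.3-fold lower number from compound 2 to compound 4 (0.14 log units; that floor lies within the scatter). In this assay, the expected value for compound 4 is 35000 nM, within an estimated range of 10000 nM to 70000 nM.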

Compound 4, half-maximal cytotoxic concentration: 25000 nM
For compound 4 the middle estimate is 1.4-fold (0.15 log units) above the measured one; the measured number falls inside the stated range.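

In this assay, going by these compounds alone, amino in place of nitro, ortho to a (4-cyanophenyl)amino group, gives the first step at this position with a readable size: an at least 1.9-fold lower number from compound 2 to compound 4 (0.28 log units; that floor lies within the scatter). Compound 2 remains a limit, so this size is only a floor: the limit of > 48700 nM in this assay, at which 1 of the 4 values shown sits. The other step, which also starts from a limit, cannot be read.

From the compounds shown here alone, the true size of the change therefore remains open, including whether it goes beyond the scatter. Going by these compounds, how a hydroxyl or an acetamide group would read at this position also remains open.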